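Phenyl in place of isopropyl, growth inhibition

The compounds below may be only part of what the source reports. "The series", "measured", "known", "first", "only" and "open" are said of these compounds alone.

Compound 1 `COC(=O)c1nc(C)n(-c2ccc(C(F)(F)F)cc2)n1` and compound 2 `COC(=O)c1nc(C(C)C)n(-c2ccc(F)cc2)n1` were both run in a functional assay on NPC-TW01 cells (Homo sapiens) for inhibition, read by MTT assay, with a stated time of 72 h; on this read-out higher numbers stand for weaker inhibition of growth and lower numbers for stronger inhibition of growth. For compound 1 the result is only a limit, > 100000 nM. For compound 2 the result is likewise only a limit, > 100000 nM. Within the data shown here, compound 2 thus sits at the limit of > 100000 nM in this assay, at which 2 of the 2 values shown sit, and no measured step between the two compounds is available. Compound 3 `COC(=O)c1nc(-c2ccccc2)n(-c2ccc(F)cc2)n1` carries phenyl in place of isopropyl on an aromatic carbon. Among the measured compounds shown here, no step of this kind has been measured, so no shift beyond the scatter is expected in this assay. The expected step that the limit leaves unreadable from compound 2 to compound 3 is near none. For compound 3 the expected value is 150000 nM, within 40000 nM to 600000 nM, most likely again only a limit.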

Compound 3, concentration for 50% growth inhibition: 15600 nM
Compound 3: the middle estimate sits 9.6-fold (0.98 log units) above what was measured, outside the stated range (below it).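

In this assay, phenyl in place of isopropyl on this aromatic carbon gives an at least 6.4-fold lower number from compound 2 to compound 3 (0.80 log units; beyond the scatter), so growth inhibition at this position responds to the group it carries. Compound 3 is the first compound shown with a value that is not a limit. Compound 2 stands only at a limit, so the step is a minimum and its full size stays unread: the limit of > 100000 nM in this assay, at which 2 of the 3 values shown sit.

From the compounds shown here alone, whether the step needs an aromatic ring stays open, as a cyclohexyl group or a pyridyl ring on this carbon would test. Also open, going by these compounds, is whether a carboxylic acid could replace the methoxycarbonyl group.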